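Swapping the Ethyl Ester for a tert-Butyl Ester

This account rests on a few compounds, and the source may have more. Where it says the series, first, only, none or still open, it means among the compounds named here.

Of the compounds shown here, three built on one shared core have been measured in a functional assay on HEK293 cells for agonist activity at Vasopressin V2 receptor (Homo sapiens), read by a luciferase reporter and cAMP accumulation; on this read-out lower numbers stand for an effect already at smaller amounts and higher numbers for an effect only at larger amounts of compound. Compound 1 `Cc1cc(C(=O)N2CCCCc3ccccc32)ccc1CNC(=O)Nc1c(F)cccc1F` gives 2.1 nM. Compound 2 `Cc1cc(C(=O)N2CCCCc3ccccc32)ccc1CNC(=O)NCC(=O)O` gives 180 nM, and compound 3 `CCOC(=O)CNC(=O)NCc1ccc(C(=O)N2CCCCc3ccccc32)cc1C` gives 140 nM. Among these three numbers compound 3 stands second highest. Its nearest neighbour is compound 2, and the step of a 1.3-fold lower number from compound 2 to compound 3 (0.11 log units; within the scatter) lies within the scatter, so the two values show no real difference. Its furthest neighbour is compound 1, and the step of a 67-fold higher number from compound 1 to compound 3 (1.82 log units; beyond the scatter) is large, as is the step of an 86-fold higher number from compound 1 to compound 2 (1.93 log units; beyond the scatter); both of those large steps come from exchanging the 2,6-difluorophenyl group, a different part of the molecule.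

Compound 4 `Cc1cc(C(=O)N2CCCCc3ccccc32)ccc1CNC(=O)NCC(=O)OC(C)(C)C` has not yet been measured. It differs from compound 3 in a single place: tert-butyl in place of ethyl on an oxygen next to a carbonyl group. Among the measured compounds shown here, the only measured step that touches this same oxygen next to a carbonyl group is a 1.3-fold lower number from compound 2 to compound 3 (0.11 log units; within the scatter), and that step stayed within the scatter. On that basis, the step of a 1.1-fold higher number from compound 3 to compound 4 (0.03 log units; within the scatter) is expected to remain within the scatter as well, with no clear direction. Compound 4 is therefore estimated to give 150 nM in this assay, with a likely range from 60 nM to 400 nM.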

Compound 4, half-maximal effective concentration: 120 nM
The estimate for compound 4 lay 1.3-fold (0.10 log units) above the measured number; low and high end bracket the measured number.
By their numbers in this assay, from the lowest: compound 1; then compounds 4, 3 and 2 (each within the scatter of the next).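

In this assay, the oxygen next to a carbonyl group has now been seen carrying hydrogen, ethyl and tert-butyl, and going from 2 to 4 heavy atoms on it gives a step that stays within the scatter (a 1.2-fold lower number from compound 3 to compound 4 (0.07 log units; within the scatter)), as does the full exchange of hydrogen for tert-butyl (a 1.5-fold lower number from compound 2 to compound 4 (0.18 log units; within the scatter)). Compounds 2, 3 and 4 therefore show no real difference, so across these three endings the identity of the group on this oxygen has no readable effect on the result. The large gap to the 2,6-difluorophenyl compound remains with the bulkier ester (a 57-fold higher number from compound 1 to compound 4 (1.76 log units; beyond the scatter)), which means that the tert-butyl ester does not bring back what separates the (tert-butoxycarbonyl)methyl group from 2,6-difluorophenyl on the amide-type nitrogen.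

Nothing available here explains why the values at this oxygen stay so close together. As far as these compounds go, it also remains open whether this flat behaviour extends beyond these three endings, for instance to a benzyl group on the same oxygen, or to a primary amide or a longer chain in place of the whole ester.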